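This account rests on a few compounds, and the source may have more. Where it says the series, first, only, none or still open, it means among the compounds named here.

Of the compounds shown here, three have been measured in an in vivo functional assay on the whole organism for inhibition of 3-hydroxy-3-methylglutaryl-coenzyme A reductase (Rattus norvegicus), at a dose of 2 mg/kg by the oral route (on this read-out higher numbers stand for a stronger effect at the one dose given and lower numbers for a weaker effect), and a fourth is still waiting. Compound 1, `Cc1cc2c(-c3ccc(F)cc3)c(/C=C/[C@@H](O)C[C@@H](O)CC(=O)O)c(C(C)C)nc2s1`, gives 34.2% in this assay. Compound 2, `CC(C)c1cc2c(-c3ccc(F)cc3)c(/C=C/[C@@H](O)C[C@@H](O)CC(=O)O)c(C(C)C)nc2s1`, gives -19.3%. These two share a core and differ in one place: methyl in place of isopropyl on an aromatic carbon. That single swap made a number 53.5 percentage points higher from compound 2 to compound 1 (beyond the scatter). Compound 3, `CC(C)c1cc2nc(C3CC3)c(/C=C/[C@@H](O)C[C@@H](O)CC(=O)O)c(-c3ccc(F)cc3)n2n1`, gives -19.4%, a value that lies within the scatter of the value of compound 2. Compound 3 has a different core from compound 2; the difference between the two cores is not broken down here.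

Compound 4, `Cc1cc2nc(C3CC3)c(/C=C/[C@@H](O)C[C@@H](O)CC(=O)O)c(-c3ccc(F)cc3)n2n1`, has not yet been measured. It differs from compound 3 in one place: methyl in place of isopropyl on an aromatic carbon. Within the data shown here, this is the same kind of change as the one from compound 2 to compound 1, but the surroundings differ: in compound 2 the isopropyl sits on a five-membered aromatic ring with 1 sulfur, next to the ring sulfur, whereas in compound 3 it sits on a five-membered aromatic ring with 2 nitrogen, next to the ring nitrogen, two ring bonds from the ring nitrogen.

A rise is expected because compound 3 starts at -19.4%, close to where compound 2 started, and because the earlier swap brought a number 53.5 percentage points higher from compound 2 to compound 1 (beyond the scatter). Confidence is lower, since the core is different. On that basis, the expected step is a number 34.4 percentage points higher from compound 3 to compound 4 (beyond the scatter). Compound 4 is expected to give about 15%, most likely between -15% and 45%.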

Compound 4, a percentage reported as inhibition, in the whole organism at one dose (the size of the read-out at that dose, not a potency): 6.5%
Compound 4: middle estimate off by 8.5 percentage points, on the high side; measured number inside the range.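

Replacing isopropyl with methyl on an aromatic carbon raised the number on both cores in this assay, and the core of compound 3 gave a number 25.9 percentage points higher from compound 3 to compound 4 (beyond the scatter) for this swap. The direction of the change therefore carried over from one core to the other, but its size did not: the same change on two cores in this assay, a number 53.5 percentage points higher (beyond the scatter) from compound 2 to compound 1 and a number 25.9 percentage points higher (beyond the scatter) from compound 3 to compound 4, 27.6 percentage points apart, beyond the scatter of two such steps. Among these compounds, this is only one pair of compounds on each core, so it does not show why the step differs in size, nor does it predict how large the step would be on a third core, and a percentage at a single dose is not a measure of potency.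

The compounds shown carry only methyl or isopropyl at this aromatic carbon, so it remains open how an ethyl group, a longer chain or an amine would read there on either core, and whether the number changes steadily with the size of the group or peaks at methyl. Also open, going by these compounds, is whether the swap would give a similar difference at other doses, as all four numbers describe the effect at one oral dose in the whole animal.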